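The source may report more compounds than this note shows. Statements on the series, on what has been measured and on what is new or still open speak of the compounds shown alone.

Compound 1 `Oc1ccccc1CNc1ccc(-c2ccc(Cl)cc2)cc1` and compound 2 `N#Cc1ccc(-c2ccc(NCc3ccccc3O)cc2)cc1` share one core and differ only in the group on the far ring. In a functional assay on Jurkat cells (Homo sapiens) for activation, with a stated time of 24 h (on this read-out lower numbers stand for an effect already at smaller amounts and higher numbers for an effect only at larger amounts of compound), compound 1 gives 2390 nM, whereas in the same assay compound 2 is recorded as "not active" (no number reported), with no concentration reported for it. Among the measured compounds shown here, compound 2 therefore stands below everything that carries a number: it is the one member without a measurable effect. The untested member is compound 3 `CCCOc1ccc(-c2ccc(NCc3ccccc3O)cc2)cc1`, which keeps the whole of compound 2 apart from one change, (propoxy in place of cyano on an aromatic carbon). For the measured compounds named here, as no step between measured compounds is available, the size of the change in this assay cannot be anchored to a known pair; the expectation is a move toward an effect at smaller amounts than compound 2 shows, since compound 2 gives no number at all, but whether that move carries compound 3 into the range of compound 1 is open. Compound 3 is estimated to give 3500 nM in this assay, with a range from 900 nM to 15000 nM.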

Compound 3, half-maximal effective concentration: "not active" (no number reported)
Compound 3 has no reported number here, so the estimate cannot be set against anything.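

Among the compounds shown here, compound 2 and compound 3 both carry no number in this assay, so no step between them can be read. Nothing shown here accounts for this result. The compounds shown leave open what in the group on the far ring separates compound 1 at 2390 nM from compound 2 and compound 3.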